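A few compounds are considered here, and "the series" means these few. Any claim that something is new, unique, unknown or untested is made for them only; others in the source may bear on it.

Measured so far in a functional assay on A549 cells (Homo sapiens) for antiproliferative activity, read by MTT assay; a higher number here means a weaker inhibitor, a lower number a stronger inhibitor:
- compound 1 `Cc1cccc(/C=N/Nc2ncc3c(n2)n(C2CCCC2)c(=O)c(=O)n3C)c1`: 34500 nM
- compound 2 `Cc1cc(C)c(/C=N/Nc2ncc3c(n2)n(C2CCCC2)c(=O)c(=O)n3C)c(C)c1`: 12000 nM

Compound 1 stands highest of the two numbers in this assay; its nearest neighbour is compound 2, reached by a 2.9-fold lower number from compound 1 to compound 2 (0.46 log units; beyond the scatter), a modest step beyond the scatter through a change of the aryl group on the carbon with a double bond to nitrogen.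

Compound 3 `COc1ccc(/C=N/Nc2ncc3c(n2)n(C2CCCC2)c(=O)c(=O)n3C)cc1` is not yet measured. It differs from compound 1 by 4-methoxyphenyl in place of 3-methylphenyl on a carbon with a double bond to nitrogen. For the measured compounds named here, the only measured step that bears on it is the one from compound 1 to compound 2, which also changes the aryl group at the same place and gave a modest lowering. Going by the values given here, no step shows a methoxy-bearing aryl here. A change at this position is therefore expected to move the number by at most a modest amount, if at all, with direction uncertain but a slight lowering being the nearer guess.

For compound 3 the expected value is 25000 nM, with a range from 9000 nM to 70000 nM. This estimate means a step of a 1.4-fold lower number from compound 1 to compound 3 (0.14 log units; within the scatter).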

Compound 3, half-maximal inhibitory concentration: > 100000 nM
Compound 3: only a limit was reported (the forecaster's own chance of this, stated with the estimate: 10%); middle value at least 4.0-fold (0.60 log units) away from the limit.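

In this assay, the aryl group on a carbon with a double bond to nitrogen can raise the number as well as lower it: 4-methoxyphenyl in place of 3-methylphenyl gives an at least 2.8-fold higher number from compound 1 to compound 3 (0.46 log units; beyond the scatter). Compound 3 stands at a limit of the assay and not at a number: the limit of > 100000 nM in this assay, at which 1 of the 3 values shown sits. Replacing 2,4,6-trimethylphenyl with 4-methoxyphenyl gives an at least 8.3-fold higher number from compound 2 to compound 3 (0.92 log units; beyond the scatter), so this position spans a wider spread than compound 1 and compound 2 alone showed.

The change from 3-methylphenyl to 4-methoxyphenyl alters both the group and its place on the ring, and no pair shown separates these two differences. Going by these compounds, how a plain phenyl, a 4-methylphenyl, a 3-methoxyphenyl or an aryl amine would read at this position remains open.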